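This account rests on a few compounds, and the source may have more. Where it says the series, first, only, none or still open, it means among the compounds named here.

Of the compounds shown here, three that share one core have so far been measured in a functional assay on RAW264.7 cells (Mus musculus) for inhibition, read by Griess assay, with stated times of 2 h and 24 h; on this read-out higher numbers stand for weaker inhibition and lower numbers for stronger inhibition. Compound 1 `CCCn1cc(COc2cc(O)c3c(c2)O[C@H](c2ccc(OC)c(O)c2)CC3=O)nn1` bears a propyl group on an aromatic nitrogen and gives 9670 nM. Compound 2 `COc1ccc([C@@H]2CC(=O)c3c(O)cc(OCc4cn(Cc5ccccc5F)nn4)cc3O2)cc1O` gives 7320 nM, and compound 3 `COc1ccc([C@@H]2CC(=O)c3c(O)cc(OCc4cn(Cc5ccc(F)cc5)nn4)cc3O2)cc1O` gives 15100 nM. On these numbers compound 1 stands second highest of the three: its nearest neighbour is compound 2, with a 1.3-fold lower number from compound 1 to compound 2 (0.12 log units; within the scatter), and its furthest is compound 3, with a 1.6-fold higher number from compound 1 to compound 3 (0.19 log units; within the scatter), so neither exchange takes compound 1 beyond the scatter. Among the compounds with values here, the only step that does exceed the scatter is a 2.1-fold higher number from compound 2 to compound 3 (0.31 log units; beyond the scatter), and it is modest.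

Compound 4 `COc1ccc([C@@H]2CC(=O)c3c(O)cc(OCc4cn(C5CCC5)nn4)cc3O2)cc1O` has not yet been measured. It differs from compound 1 by cyclobutyl in place of propyl on an aromatic nitrogen. Within the data shown here, no measured step exchanges propyl for cyclobutyl, so the closest guide is how compound 1 behaved in this assay when its propyl group was replaced by other groups in compound 2 and compound 3, where both steps stayed within the scatter. The expected step is therefore a 1.1-fold lower number from compound 1 to compound 4 (0.03 log units; within the scatter), which is no change beyond the scatter. Compound 4 is estimated to give 9000 nM in this assay, with a range from 4500 nM to 20000 nM.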

Compound 4, half-maximal inhibitory concentration: 15300 nM
Beside the measured number, compound 4's estimate is 1.7-fold (0.23 log units) below it; the range from low to high includes it.
By their numbers in this assay, from the lowest: compounds 2, 1, 3 and 4 (each within the scatter of the next, the first and the last beyond it).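

In this assay, cyclobutyl in place of propyl on the aromatic nitrogen gives a 1.6-fold higher number from compound 1 to compound 4 (0.20 log units; within the scatter), so at this position a four-membered carbon ring and the open propyl chain cannot be told apart. Set against the 4-fluorobenzyl group, cyclobutyl gives a 1.0-fold higher number from compound 3 to compound 4 (0.01 log units; within the scatter), whereas set against the 2-fluorobenzyl group it gives a 2.1-fold higher number from compound 2 to compound 4 (0.32 log units; beyond the scatter), a second modest step beyond the scatter leading away from the 2-fluorobenzyl group, although that group itself stays within the scatter of propyl. Nothing measured here accounts for these steps, and the data offer no independent information on what the groups at this position do.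

The compounds shown leave open whether other carbon rings, such as cyclopropyl or cyclohexyl, or a longer chain, such as hexyl, would stay within this same narrow band of values. They also leave open how unsubstituted benzyl or 3-fluorobenzyl would compare with the two fluorinated benzyl groups, and whether an amine or a carboxylic acid carried on the aromatic nitrogen would move the number any further.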